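A few compounds are considered here, and "the series" means these few. Any claim that something is new, unique, unknown or untested is made for them only; others in the source may bear on it.

Compound 1 `COc1cc2nc(N3CCN(S(=O)(=O)c4ccc(I)cc4)CC3)nc(N)c2cc1OC` and compound 2 `COc1cc2nc(N3CCN(S(=O)(=O)c4ccc(C(C)(C)C)cc4)CC3)nc(N)c2cc1OC` share one core and differ only in the group on the outer aromatic ring. In a functional assay on PC-3 cells (Homo sapiens) for inhibition (on this read-out higher numbers stand for weaker inhibition and lower numbers for stronger inhibition), compound 1 gives 15000 nM. In this assay, going by the values given here, compound 2 gives 4100 nM, and the single step of a 3.7-fold lower number from compound 1 to compound 2 (0.56 log units; beyond the scatter) shows that this exchange of a larger carbon group for a halogen moved the number down modestly. Among the compounds with values here, on the two numbers known so far, compound 2 stands with the lowest value, with compound 1 as its nearest neighbour at the higher number.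

Compound 3 `COc1cc2nc(N3CCN(S(=O)(=O)c4ccc(-c5ccc(C(F)(F)F)cc5)cc4)CC3)nc(N)c2cc1OC` is the next step from compound 2, with 4-(trifluoromethyl)phenyl in place of tert-butyl on an aromatic carbon. Within the data shown here, only the step of a 3.7-fold lower number from compound 1 to compound 2 (0.56 log units; beyond the scatter) bears on this change, and it concerns a different replacement at the same position, so the guidance is thin. Since the one known enlargement at this position lowered the number, a further, larger aromatic group is expected to move this assay down again by a modest amount, a 2.1-fold lower number from compound 2 to compound 3 (0.31 log units; beyond the scatter), though it could equally stay within the scatter. The estimate for compound 3 in this assay is 2000 nM, with a range from 500 nM to 8000 nM.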

Compound 3, half-maximal inhibitory concentration: 3300 nM
Compound 3: middle estimate off by 1.7-fold (0.22 log units), on the low side; low and high end bracket the measured number.
By their numbers in this assay, from the lowest: compounds 3 and 2 (each within the scatter of the next); then compound 1.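

In this assay the exchange of tert-butyl, with 4 heavy atoms and no ring, for 4-(trifluoromethyl)phenyl, with 10 heavy atoms and one six-membered aromatic ring of carbon only, gives a 1.2-fold lower number from compound 2 to compound 3 (0.09 log units; within the scatter), so this much added size leaves the number where it was. Measured against the iodo group, the new group gives a 4.5-fold lower number from compound 1 to compound 3 (0.66 log units; beyond the scatter), a step beyond the scatter, and compound 2 and compound 3 therefore stand together on the lower side of compound 1, so the drop seen earlier at this position does not continue with further enlargement across these three compounds. Nothing available explains why the iodo group differs from the other two or why those two do not differ from each other.

Both groups in compound 2 and compound 3 carry 0 hydrogen-bond donors and 0 hydrogen-bond acceptors, so the compounds shown leave open how an amine or a carboxylic acid at this position would read in this assay. They also leave open whether the trifluoromethyl on the outer ring matters, which a plain phenyl group in the same place would show.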